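Chloro on the benzoxazole ring: notes toward compound 3

A few compounds are considered here, and "the series" means these few. Any claim that something is new, unique, unknown or untested is made for them only; others in the source may bear on it.

Measured so far:
compound 1, `Cn1c(-c2ccc(NC(=O)CCl)cc2)nc(-c2ccccc2)c1-c1ccccc1`, 4.3%
compound 2, `Cn1c(-c2ccc(NC(=O)CSc3nc4ccccc4o3)cc2)nc(-c2ccccc2)c1-c1ccccc1`, 27.4%

Going by the values given here, in a functional assay on MCF7 cells (Homo sapiens) for cytotoxicity, read by MTT assay, with a stated time of 24 h, tested at 1.6 ug/mL (a higher number here means a stronger effect of the compound at the concentration tested, a lower number a weaker effect), compound 2 gives the higher of the two numbers; the only other value is that of compound 1, and the gap is a number 23.1 percentage points higher from compound 1 to compound 2 (beyond the scatter). That is the whole record of steps in this assay.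

Compound 3, `Cn1c(-c2ccc(NC(=O)CSc3nc4cc(Cl)ccc4o3)cc2)nc(-c2ccccc2)c1-c1ccccc1`, differs from compound 2 in one place: chloro in place of hydrogen on an aromatic carbon. Among the compounds with values here, no measured step touches this position or this kind of change; the single step known, a number 23.1 percentage points higher from compound 1 to compound 2 (beyond the scatter), concerns the exchange of the whole (1,3-benzoxazol-2-yl)sulfanyl group for chloro at the chain carbon, not a substituent on the fused ring. The change to compound 3 is small in count, and without any bearing step the expectation is a step that may fall within the scatter. Compound 3 is expected to land near compound 2, with an expected step of a number 2.6 percentage points higher from compound 2 to compound 3 (within the scatter), so the estimate for compound 3 is 30% (range 14% to 50%).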

Compound 3, a percentage reported as activity, at one concentration (the size of the read-out at that concentration, not a potency): 2.5%
Compound 3: the middle estimate sits 27.5 percentage points above what was measured; measured number below the stated range.
By their numbers in this assay, from the lowest: compounds 3 and 1 (each within the scatter of the next); then compound 2.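

In this assay the fused ring of the 1,3-benzoxazol-2-yl group proves to be no neutral spot, since one chloro in place of hydrogen on an aromatic carbon there gives a number 24.9 percentage points lower from compound 2 to compound 3 (beyond the scatter) and removes the whole gain that compound 2 had shown. Set against the chloro on the chain carbon, the (5-chloro-1,3-benzoxazol-2-yl)sulfanyl group gives a number 1.8 percentage points lower from compound 1 to compound 3 (within the scatter) and so brings the series back to the level of compound 1. Nothing available explains why this single atom has so large an effect.

As far as these compounds go, whether a fluoro, a methyl or a methoxy group on the same carbon would do the same remains open, as does the outcome for chloro on another carbon of that ring. From the compounds shown here alone, with this assay read at one concentration, these numbers show only a stronger or weaker effect at that concentration, and how the compounds would compare at other concentrations also remains open.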